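Carbamoyl on the Ring Nitrogen of Compound 1

The source may hold more compounds than are shown below. What is called first, only, known or untested is meant among the compounds shown, and "the series" means these compounds.

Compound 1 `O=C1NC(c2ccccc2)CN1S(=O)(=O)c1ccc2c(c1)CCCN2` carries a free hydrogen on the ring nitrogen of its core, and in a functional assay on SK-OV-3 cells (Homo sapiens) for antiproliferative activity, read by MTT assay (on this read-out higher numbers stand for weaker inhibition and lower numbers for stronger inhibition), compound 1 gives 10400000 nM, the highest of the three numbers measured. Two acylated analogues sit far below it. Compound 2 `CC(C)COC(=O)N1CCCc2cc(S(=O)(=O)N3CC(c4ccccc4)NC3=O)ccc21` gives 5650 nM, and compound 3 `O=C(OCCCl)N1CCCc2cc(S(=O)(=O)N3CC(c4ccccc4)NC3=O)ccc21` gives 9800 nM. The move from the free nitrogen to the isobutoxycarbonyl group is a 1800-fold lower number from compound 1 to compound 2 (3.26 log units; beyond the scatter), and to the (2-chloroethoxy)carbonyl group it is a 1100-fold lower number from compound 1 to compound 3 (3.03 log units; beyond the scatter); between the two carbamates the step is a 1.7-fold higher number from compound 2 to compound 3 (0.24 log units; within the scatter).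

Compound 4 `NC(=O)N1CCCc2cc(S(=O)(=O)N3CC(c4ccccc4)NC3=O)ccc21` differs from compound 1 by carbamoyl in place of hydrogen on a nitrogen on an aromatic ring in a ring. No urea on this nitrogen has been measured, so the expectation rests on the two carbamates alone. Both steps that place a carbonyl-bearing group on this nitrogen were large and in the same direction, so a large drop is expected here as well, though the carbamoyl group is not a carbamate like that of compound 2 or compound 3, and the step is expected to be somewhat smaller. The expected step is a 420-fold lower number from compound 1 to compound 4 (2.62 log units; beyond the scatter). Compound 4 is therefore estimated at 25000 nM, within a range from 5000 nM to 300000 nM.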

Compound 4, half-maximal inhibitory concentration: > 20000 nM
Compound 4 gave a limit, no number (the forecaster's own chance of this, stated with the estimate: 15%); the middle value lies beyond the limit too.
By their numbers in this assay, from the lowest: compounds 2 and 3 (each within the scatter of the next); then compound 1.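

In this assay compound 4 stands at > 20000 nM, which is a limit and not a number, and its reading ends there: the limit of > 20000 nM in this assay, at which 1 of the 4 values shown sits.

The earlier compounds shown here showed only that two carbamates on this nitrogen sit far below the free nitrogen, while the step from compound 1 to compound 4 cannot be read, so a carbonyl on this nitrogen does not by itself ensure a value inside the readable range. What the new result adds concerns the group on the carbonyl carbon, which the two carbamates left unresolved as their step stayed within the scatter: amino in place of isobutoxy gives an at least 3.5-fold higher number from compound 2 to compound 4 (0.54 log units; beyond the scatter), while amino in place of 2-chloroethoxy gives an at least 2.0-fold higher number from compound 3 to compound 4 (0.30 log units; that floor lies within the scatter), a floor that does not itself clear the scatter.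

Going by these compounds, how far compound 4 really lies from compound 3 and from compound 1 remains open, as the limit allows anything from just beyond compound 3 up to the level of compound 1. Also open, on these data alone, is how a methylamino or dimethylamino group on the carbonyl carbon, or an acetyl group on the ring nitrogen, would behave at this position.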